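The source may report more compounds than this note shows. Statements on the series, on what has been measured and on what is new or still open speak of the compounds shown alone.

Measured compounds:
- compound 1 `COc1ccc(/C=C/C(=O)c2ccc(OC)c3c2OC(C)(C)C=C3)cn1`: > 10000 nM
- compound 2 `COc1ccc(C(=O)/C=C/c2ccc(OC)c(OC)c2OC)c2c1C=CC(C)(C)O2`: > 10000 nM
- compound 3 `COc1ccc(C(=O)/C=C/c2cccc(C(F)(F)F)c2)c2c1C=CC(C)(C)O2`: > 10000 nM

In a functional assay on HepG2 cells (Homo sapiens) for antiproliferative activity, read by MTT assay, with a stated time of 24 h (a higher number here means a weaker inhibitor, a lower number a stronger inhibitor), compound 1 gives > 10000 nM, which is a limit of the assay and not a number. In this assay compound 2 also gives only a limit, > 10000 nM. Compound 3 likewise gives only a limit, > 10000 nM. So compound 1 does not stand apart from the others: all three sit at the limit of > 10000 nM in this assay, at which 3 of the 3 values shown sit, and nothing separates them on the numbers shown.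

Compound 4 `COc1ccc(C(=O)/C=C/c2cc(Cl)ccc2O)c2c1C=CC(C)(C)O2` shares the core of compound 1 and differs in one place: 5-chloro-2-hydroxyphenyl in place of 6-methoxypyridin-3-yl on a double-bonded chain carbon bound to a double-bonded chain carbon. No measured pair shows what such a swap does here, so the size of the step from compound 1 to compound 4 cannot be read off any shown step. Since every measured compound sits at the limit, the expected step that the limit leaves unreadable from compound 1 to compound 4 is none beyond the scatter, with the chance of a number near or above the limit. Compound 4 is therefore estimated at 15000 nM, within 3000 nM to 60000 nM.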

Compound 4, half-maximal inhibitory concentration: 6640 nM
The estimate for compound 4 lay 2.3-fold (0.35 log units) above the measured number, and the stated range covers the measured number.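

In this assay, going by these compounds alone, compound 4 gives 6640 nM, the only value shown that is a number and not a limit. Compound 1 gives > 10000 nM, which is a limit of the assay. With 5-chloro-2-hydroxyphenyl in place of 6-methoxypyridin-3-yl, the result is an at least 1.5-fold lower number from compound 1 to compound 4 (0.17 log units; that floor lies within the scatter), so this position can give a measurable number, but the true size of the change stays unknown because the step starts from a limit: the limit of > 10000 nM in this assay, at which 3 of the 4 values shown sit.

No other step among the compounds shown can be read. On these data alone, it remains open whether the chlorine, the hydroxyl group or both matter for the number seen with compound 4, and what an amine on the same aromatic ring would do.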